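A few compounds are considered here, and "the series" means these few. Any claim that something is new, unique, unknown or untested is made for them only; others in the source may bear on it.

Working notes on the series. The shared core carries an amide-linked diaryl ether; compound 1 `COc1ccc(-n2ccc(=O)c(C(=O)Nc3ccc(Oc4ccnc5[nH]ccc45)cc3)n2)cc1` bears a 4-methoxyphenyl on an aromatic nitrogen and a free ring nitrogen-hydrogen. In a functional assay on MCF7 cells (Homo sapiens) for cytotoxicity, read by MTT assay, with a stated time of 72 h (a higher number here means a weaker inhibitor, a lower number a stronger inhibitor), compound 1 gives 21600 nM. Compound 2 `O=C(Nc1ccc(Oc2ccnc3[nH]ccc23)cc1)c1nn(-c2ccc(Cl)c(C(F)(F)F)c2)ccc1=O` replaces that 4-methoxyphenyl with 4-chloro-3-(trifluoromethyl)phenyl, and in this assay compound 2 gives 6270 nM; the step is a 3.4-fold lower number from compound 1 to compound 2 (0.54 log units; beyond the scatter). Compound 3 `COc1ccc(-n2ccc(=O)c(C(=O)Nc3ccc(Oc4ccnc5c4ccn5C)cc3)n2)cc1` instead carries a methyl on the aromatic nitrogen. For compound 3 this assay reports only a limit, > 60000 nM, at the limit of > 60000 nM in this assay, at which 1 of the 3 values shown sits. The step of an at least 2.7-fold higher number from compound 1 to compound 3 (0.44 log units; beyond the scatter) therefore places compound 3 at the weak end of the three numbers shown.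

Compound 4 `Cn1ccc2c(Oc3ccc(NC(=O)c4nn(-c5ccccc5)ccc4=O)cc3)ccnc21` is still to be measured. The change from compound 3 is hydrogen in place of methoxy on an aromatic carbon, in words: hydrogen in place of methoxy on an aromatic carbon, para to a large group. Neither measured step touches this position: one alters the whole aryl group, the other methylates a ring nitrogen. No step shown bears directly on the change, so for compound 4 no shift beyond the scatter in this assay is expected, a step that the limit leaves unreadable from compound 3 to compound 4. Compound 4 is expected to give about 70000 nM in this assay, within 25000 nM to 200000 nM, most likely again only as a limit.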

Compound 4, half-maximal inhibitory concentration: 45200 nM
Compound 4: the middle estimate sits 1.5-fold (0.19 log units) above what was measured, within the range that was stated.
By their numbers in this assay, from the lowest: compound 2; then compound 1; then compound 4. At a limit, above all of these: compound 3.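

Taking the methoxy off the 4-methoxyphenyl, para to a large group, gives the first readable number for the methylated ring nitrogen in this assay, where compound 4 gives 45200 nM. The change is read as an at least 1.3-fold lower number from compound 3 to compound 4 (0.12 log units; that floor lies within the scatter), so the loss of methoxy shows no shift beyond the scatter, while a true step larger than this floor also remains possible. For compound 3 the figure is a limit and not a number, so the size of the step stays undetermined: the limit of > 60000 nM in this assay, at which 1 of the 4 values shown sits.

Going by these compounds, the phenyl group appears here only together with the methylated ring nitrogen, so its effect alongside the free ring nitrogen-hydrogen of compound 1 remains open, as does whether the change from 4-methoxyphenyl to phenyl exceeds the scatter at all. Also open, on these data alone, is what a hydroxyl, an amine or a carboxylic acid on that aromatic carbon, para to a large group, would give in this assay, and so whether this position responds to any replacement of the methoxy.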